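The source may hold more compounds than are shown below. What is called first, only, known or untested is meant among the compounds shown, and "the series" means these compounds.

Of the compounds shown here, three have so far been measured in an assay on HeLa cells for displacement of a labelled ligand from adenosine receptor A3 (Homo sapiens), read by scintillation counting, with a stated time of 180 min, tested at 10 uM; on this read-out higher numbers stand for more inhibition at the one concentration tested (going by the name of the read-out) and lower numbers for less inhibition. Compound 1 `N=c1oc2ccc(Br)cc2cc1C(=O)NC1CCCCC1` gives 8% in this assay, compound 2 `COC(=O)/C(C#N)=C/c1cccc(OC)c1O` gives 45%, and compound 3 `COc1cccc2cc(C(=O)Nc3c(C#N)ncn3-c3ccc(C#N)cc3)c(=N)oc12` gives 1%. The number for compound 3 is the lowest of the three; its nearest neighbour is compound 1, whose number lies within the usual scatter of it, while compound 2 stands beyond the scatter above it. Compound 4 `COc1ccc(-n2cnc(C#N)c2NC(=O)c2cc3cccc(OC)c3oc2=N)cc1` has not yet been measured. It differs from compound 3 in one place: methoxy in place of cyano on an aromatic carbon. Going by the values given here, no pair of measured compounds shows this change, so there is no measured step to set its size against. Because compound 3 gives 1% in this assay, compound 4 is expected to remain in the same low region, with an expected step of a number 4 percentage points higher from compound 3 to compound 4 (within the scatter) that stays within the scatter. Compound 4 is therefore estimated at 5% in this assay, within a range from 0% to 20%.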

Compound 4, a percentage reported as inhibition, at one concentration (the size of the read-out at that concentration, not a potency): 42%
Compound 4: middle estimate off by 37 percentage points, on the low side; the measured number lies above the stated range.
By their numbers in this assay, from the lowest: compounds 3 and 1 (each within the scatter of the next); then compounds 4 and 2 (each within the scatter of the next).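

Going by these compounds alone, replacing cyano with methoxy on this aromatic carbon, the change from 4-cyanophenyl to 4-methoxyphenyl, gives a number 41 percentage points higher from compound 3 to compound 4 (beyond the scatter) in this assay and is the first measured step at this position, showing that the number here can depend strongly on the group at this one place on the ring. Cyano and methoxy have the same count of heavy atoms and of hydrogen-bond acceptors, so those counts do not separate compound 3 from compound 4. Nothing among the data shown accounts for the size of this step.

The compounds shown leave open whether an amine, a carboxylic acid or a longer ether chain such as ethoxy at this place would give a similar number. This single pair also leaves open whether the same change would give a step of similar size on another core.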